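Changing the amine substituent on a shared core

This account rests on a few compounds, and the source may have more. Where it says the series, first, only, none or still open, it means among the compounds named here.

Three compounds have been measured in a functional assay on CHO cells for agonist activity at 5-hydroxytryptamine receptor 4 (Homo sapiens), read by a luciferase reporter and cAMP accumulation, with a stated time of 4 h; a higher number here means that more compound is needed for the effect, a lower number that less compound is needed:

Compound 1 `CC(C)c1nc(-c2nnc(C3CCN(C4CCC4)CC3)o2)c2ccccn12` gives 840 nM.
Compound 2 `CC(C)c1nc(-c2nnc(C3CCN(CC4CCC4)CC3)o2)c2ccccn12` gives 520 nM.
Compound 3 `CC(C)c1nc(-c2nnc(C3CCN(C(C)C)CC3)o2)c2ccccn12` gives 500 nM.

All three share one core and differ only in the group carried on an amine nitrogen in a ring. Compound 3 gives the smallest number of the three, though a 1.7-fold lower number from compound 1 to compound 3 (0.23 log units; within the scatter) and a 1.0-fold lower number from compound 2 to compound 3 (0.02 log units; within the scatter) both lie within the scatter, so nothing separates it from the others with confidence.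

Compound 4 `COCCCN1CCC(c2nnc(-c3nc(C(C)C)n4ccccc34)o2)CC1` has not yet been measured. Its change from compound 3 is 3-methoxypropyl in place of isopropyl on an amine nitrogen in a ring

Among the compounds with values here, two measured steps bear on this: a 1.7-fold lower number from compound 1 to compound 3 (0.23 log units; within the scatter) and a 1.0-fold lower number from compound 2 to compound 3 (0.02 log units; within the scatter). Both replaced one group at this same place with another, and neither moved the number beyond the scatter. Within the data shown here, the group now entering is longer and carries an ether oxygen, something no measured compound shows, so this remains an untested direction.

From compound 3 the step to compound 4 is expected to be a 1.1-fold higher number from compound 3 to compound 4 (0.04 log units; within the scatter). Compound 4 is therefore expected to give about 550 nM, with a range from 200 nM to 1500 nM.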

Compound 4, half-maximal effective concentration: 736 nM
Beside the measured number, compound 4's estimate is 1.3-fold (0.13 log units) below it; the measured number falls inside the stated range.
By their numbers in this assay, from the lowest: compounds 3, 2, 4 and 1 (each within the scatter of the next).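

Within the data shown here, on this amine nitrogen in a ring, the 3-methoxypropyl group is the first with an ether oxygen, and in this assay it leaves the number within the scatter of all three earlier compounds. The steps are a 1.5-fold higher number from compound 3 to compound 4 (0.17 log units; within the scatter) and a 1.4-fold higher number from compound 2 to compound 4 (0.15 log units; within the scatter) and a 1.1-fold lower number from compound 1 to compound 4 (0.06 log units; within the scatter). The earlier compounds showed this only for groups made of carbon, so a longer chain with 1 hydrogen-bond acceptor now joins them, and nothing measured here accounts for these numbers.

As far as these compounds go, whether any group at this place can move the number beyond the scatter stays open. A chain ending in a hydroxyl group, a carboxylic acid or a second amine would test this, as would a chain longer than 3-methoxypropyl.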